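The source may hold more compounds than are shown below. What is called first, only, known or untested is meant among the compounds shown, and "the series" means these compounds.

Three compounds of the series have numbers in an assay on isolated protein for binding affinity to Rap guanine nucleotide exchange factor 4 (Homo sapiens), read by cAMP accumulation; a lower number here means a stronger inhibitor, a higher number a weaker inhibitor. Compound 1 `Cc1cc(C)c(Nc2ccc(F)c(F)c2)c(C)c1` gives 8700 nM; compound 2 `Cc1cc(C)c(Nc2ccc(Cl)c(C(F)(F)F)c2)c(C)c1` gives 400 nM; compound 3 `Cc1ccc(Nc2c(C)cc(C)cc2C)c(C)c1` gives 2200 nM. Among these three numbers compound 3 stands second highest: compound 1 lies above it, beyond the scatter, and compound 2 lies below it, also beyond the scatter. Going by the values given here, no step between two measured compounds that differ in a single place is available. Compound 4 `Cc1cc(C)c(Nc2c(C)cc(C)cc2C)c(C)c1` differs from compound 3 by methyl in place of hydrogen on an aromatic carbon. Among the compounds with values here, with no comparable step to lean on, only a small shift is expected, a 1.5-fold lower number from compound 3 to compound 4 (0.17 log units; within the scatter), within or at the edge of the scatter, in either direction. For compound 4 the estimate in this assay is 1500 nM, with a range from 500 nM to 5000 nM.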

Compound 4, half-maximal inhibitory concentration: 400 nM
For compound 4 the middle estimate is 3.8-fold (0.57 log units) above the measured one; measured number below the stated range.
By their numbers in this assay, from the lowest: compounds 2 and 4 (each within the scatter of the next); then compound 3; then compound 1.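

In this assay the series now has its first single-place comparison: methyl in place of hydrogen on an aromatic carbon, ortho to a large group and meta to two methyl groups, gives a 5.5-fold lower number from compound 3 to compound 4 (0.74 log units; beyond the scatter). This position therefore responds to the change, by a step beyond the scatter. Nothing measured here accounts for the size of that step.

As far as these compounds go, whether a chlorine, a methoxy group or an amine in this place would act as methyl does stays open. So does whether methyl here would give a similar step in compound 1 or compound 2.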